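A Larger Acyl Group on the Shared Core

This account rests on a few compounds, and the source may have more. Where it says the series, first, only, none or still open, it means among the compounds named here.

The study begins with compound 1, `O=C1NCCc2nc(C#Cc3ccccc3)sc21`, whose ring carries the carbonyl as a lactam. In an assay on HEK293 cells for positive allosteric modulation of metabotropic glutamate receptor 5 (Homo sapiens), read by FLIPR, with a stated time of 1 h (a lower number here means that less compound is needed, a higher number that more compound is needed for the effect), compound 1 gives 112 nM. Compound 2, `CCC(=O)N1CCc2nc(C#Cc3ccccc3)sc2C1`, moves the carbonyl out of the ring onto a propanoyl group on the amide-type nitrogen. In this assay compound 2 reaches only the limit of the assay, > 10000 nM, so no number is known for it. This limit is the only thing the assay reports for compound 2 (the limit of > 10000 nM in this assay, at which 1 of the 2 values shown sits), and it places compound 2 at the far end of the two values shown.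

Compound 3, `O=C(C1CCCC1)N1CCc2nc(C#Cc3ccccc3)sc2C1`, is not yet measured. It differs from compound 2 in one place: cyclopentyl in place of ethyl on a carbonyl carbon

Going by the values given here, no step between two measured compounds is known here, so the size of the change from compound 2 to compound 3 can only be guessed. A move of an at least 2.5-fold lower number from compound 2 to compound 3 (0.39 log units; beyond the scatter) is expected in this assay, toward a lower number, though a second limit remains quite possible. Compound 3 is expected to give about 4000 nM in this assay, within a range from 500 nM to 30000 nM.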

Compound 3, half-maximal effective concentration: 19 nM
The estimate for compound 3 lay 210-fold (2.32 log units) above the measured number; measured number outside the range, below it.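

On the carbonyl carbon whose other neighbour is the amide-type nitrogen in a ring, the group proves decisive in this assay: cyclopentyl in place of ethyl brings an at least 520-fold lower number from compound 2 to compound 3 (2.72 log units; beyond the scatter). Compound 2 alone left it unclear whether an acyl group on this nitrogen could give a measurable effect at all, and compound 3, with its cyclopentylcarbonyl in place of propanoyl, shows that it can. The value of compound 2, > 10000 nM, is a limit and not a number, so the step gives only the smallest size the change can have, and its true size stays unknown: the limit of > 10000 nM in this assay, at which 1 of the 3 values shown sits.

The compounds shown do not tell whether the gain goes with the five-membered non-aromatic ring of carbon only or simply with the larger number of carbons, a question that an open chain such as pentyl or branched isopropyl on the same carbonyl would address. They also leave open how far this position tolerates other groups, such as a smaller cyclopropyl, a larger cyclohexyl, or a phenyl ring.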